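Swapping 3-methylphenyl for 2-fluorophenyl on compound 1

The source may report more compounds than this note shows. Statements on the series, on what has been measured and on what is new or still open speak of the compounds shown alone.

Within the data shown here, in an ADME assay on microsomes from liver (Mus musculus) for metabolic stability, read by LC-MS, using NADPH, with a stated time of 10 min, tested at 0.1 uM (on this read-out lower numbers stand for slow clearance and higher numbers for fast clearance), compound 1 (`Cc1cccc(N2C(=O)CSC2c2cccc(C(=O)NCCCCc3ccccc3)c2)c1`) gives 2940 mL.min-1.g-1 and holds the higher of the two numbers so far, while compound 2 (`Cc1ccnc(N2C(=O)CSC2c2cccc(C(=O)NCCCCn3cccn3)c2)c1`) gives 392 mL.min-1.g-1 in this assay and the gap between them lies beyond the scatter. Among the measured compounds shown here, no measured pair in this small set differs in one place only, so the expectation rests on the structural change alone.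

Compound 3 (`O=C(NCCCCc1ccccc1)c1cccc(C2SCC(=O)N2c2ccccc2F)c1`) has 2-fluorophenyl in place of 3-methylphenyl on an amide-type nitrogen in a ring and keeps the rest of compound 1 unchanged.

No step beyond the scatter is expected in this assay for this swap, with a slight lean towards lower numbers. The estimated step of a 1.5-fold lower number from compound 1 to compound 3 (0.17 log units; within the scatter) stays within the usual scatter. Compound 3 is expected at an estimated 2000 mL.min-1.g-1 (range 900 mL.min-1.g-1 to 4000 mL.min-1.g-1).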

Compound 3, intrinsic clearance in microsomes: 2010 mL.min-1.g-1
Compound 3: middle estimate off by 1.0-fold (0.00 log units), on the low side, and the stated range covers the measured number.
By their numbers in this assay, from the lowest: compound 2; then compounds 3 and 1 (each within the scatter of the next).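

In this assay, among these compounds, compound 3 gives the first comparison that differs in one place only, and the step of a 1.5-fold lower number from compound 1 to compound 3 (0.17 log units; within the scatter) shows that 2-fluorophenyl and 3-methylphenyl stand level on the amide-type nitrogen in a ring. For this one swap, the position does not separate the two groups beyond the scatter, and clearance in this pair stays at the level set by compound 1. No supporting measurement bears on this result.

Compound 2 differs from compound 1 and compound 3 in more than one place, so the part responsible for the value of compound 2 at 392 mL.min-1.g-1 remains unassigned. As far as these compounds go, whether a carboxylic acid or a morpholine on this nitrogen would produce a step beyond the scatter also remains open.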